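A methoxy in place of a methyl

The source may report more compounds than this note shows. Statements on the series, on what has been measured and on what is new or still open speak of the compounds shown alone.

Measured in a functional assay on MCF7 cells (Homo sapiens) for antiproliferative activity, read by sulforhodamine B assay, with a stated time of 48 h; a lower number here means a stronger inhibitor, a higher number a weaker inhibitor:
Compound 1 `CN1CCN(c2ccc(S(=O)(=O)Oc3cccc(I)c3)cc2)C1=O`: 560 nM
Compound 2 `COc1ccc(OS(=O)(=O)c2ccc(N3CCN(C)C3=O)cc2)cc1OC`: 12000 nM
Compound 3 `Cc1ccc(OS(=O)(=O)c2ccc(N3CCN(C)C3=O)cc2)cc1`: > 100000 nM

Compound 3 gives no number, only a limit, and that is the limit of > 100000 nM in this assay, at which 1 of the 3 values shown sits.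

Compound 4 `COc1ccc(OS(=O)(=O)c2ccc(N3CCN(C)C3=O)cc2)cc1` carries methoxy in place of methyl on an aromatic carbon, para to a large group (methoxy in place of methyl on an aromatic carbon).

Going by the values given here, the only measured step reaching compound 3 is an at least 170-fold higher number from compound 1 to compound 3 (2.25 log units; beyond the scatter), with 4-methylphenyl in place of 3-iodophenyl on an oxygen. Among the compounds with values here, no measured step isolates the methyl-to-methoxy change itself. Compound 2, which also carries methoxy, gives 12000 nM in this assay, so a lower number is expected. The expected move is an at least 3.3-fold lower number from compound 3 to compound 4 (0.52 log units; beyond the scatter). Compound 4 is estimated at 30000 nM, with an expected range of 6000 nM to 100000 nM.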

Compound 4, half-maximal inhibitory concentration: 95000 nM
Estimate against measurement, compound 4: 3.2-fold (0.50 log units) below; the measured number falls inside the stated range.
By their numbers in this assay, from the lowest: compound 1; then compound 2; then compound 4. At a limit, above all of these: compound 3.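

Compound 3 gives only a limit, not a number: the limit of > 100000 nM in this assay, at which 1 of the 4 values shown sits. Read against that limit, there is an at least 1.0-fold lower number from compound 3 to compound 4 (0.02 log units; that floor lies within the scatter), so the change from methyl to methoxy has no firm size here. In this assay there is a 7.9-fold higher number from compound 2 to compound 4 (0.90 log units; beyond the scatter) with hydrogen in place of methoxy, so the extra methoxy of compound 2 counts and the single methoxy does not hold that level. There is also a 170-fold higher number from compound 1 to compound 4 (2.23 log units; beyond the scatter) with 4-methoxyphenyl in place of 3-iodophenyl.

The compounds shown leave open how an amine or an ethoxy group on this same aromatic carbon would read.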